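Dimethylamide to hydroxyethylamide on a shared core

A few compounds are considered here, and "the series" means these few. Any claim that something is new, unique, unknown or untested is made for them only; others in the source may bear on it.

Going by the values given here, compound 2 `CC(C)OC(=O)N1CCC(n2ncc3cc(-c4cc(F)c(C(=O)N(C)C)cc4F)ncc32)CC1` gives 46 nM in a functional assay on HEK293 cells for agonist activity at Glucose-dependent insulinotropic receptor (Homo sapiens), read by cAMP accumulation, with a stated time of 30 min (a lower number here means that less compound is needed, a higher number that more compound is needed for the effect), the lower of the two numbers measured so far. Compound 1 `CC(C)OC(=O)N1CCC(n2ncc3cc(Oc4ccc(S(C)(=O)=O)cc4)ncc32)CC1`, which carries a different side chain on the shared core, gives 177 nM in this assay, a gap beyond the usual scatter. Compound 3 `CC(C)OC(=O)N1CCC(n2ncc3cc(-c4cc(F)c(C(=O)NCCO)cc4F)ncc32)CC1` differs from compound 2 by (2-hydroxyethyl)amino in place of dimethylamino on a carbonyl carbon. Among the compounds with values here, no measured pair isolates this change, so only a small step in either direction, possibly none beyond the scatter, is expected. Compound 3 is expected to give 70 nM, between 25 nM and 200 nM. The step expected here is a 1.5-fold higher number from compound 2 to compound 3 (0.18 log units; within the scatter).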

Compound 3, half-maximal effective concentration: 92 nM
Compound 3: middle estimate off by 1.3-fold (0.12 log units), on the low side, within the range that was stated.
By their numbers in this assay, from the lowest: compounds 2, 3 and 1 (each within the scatter of the next, the first and the last beyond it).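

In this assay, the first pair differing in one place gives a 2.0-fold higher number from compound 2 to compound 3 (0.30 log units; within the scatter), so the two compounds cannot be told apart. On this carbonyl carbon, (2-hydroxyethyl)amino, with 2 hydrogen-bond donors, can thus stand in place of dimethylamino, with 0, without a step beyond the scatter. No evidence on the cause of this result is available.

The compounds shown leave open whether a longer chain, such as (3-hydroxypropyl)amino, or an amine-bearing chain, such as (2-aminoethyl)amino, would keep the number in the same range on this carbonyl carbon.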